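The source may hold more compounds than are shown below. What is called first, only, known or untested is meant among the compounds shown, and "the series" means these compounds.

In a functional assay on COLO 320 cells (Homo sapiens) for cytotoxicity, read by MTT assay, with a stated time of 4 h (a lower number here means a stronger inhibitor, a higher number a weaker inhibitor), compound 1 (`CCCCCCCCCCCC(=O)OC[C@H]1O[C@@H](O[C@@H]2OC=C(C(=O)OC)[C@H]3C[C@H](OC(C)=O)[C@H](C)[C@@H]23)[C@H](OC(C)=O)[C@@H](OC(C)=O)[C@@H]1OC(C)=O`) gives 0.04 ug/mL and compound 2 (`COC(=O)C1=CO[C@@H](O[C@@H]2O[C@H](COC(=O)C=C(C)C)[C@@H](OC(C)=O)[C@H](OC(C)=O)[C@H]2OC(C)=O)[C@@H]2[C@@H](C)[C@@H](OC(C)=O)C[C@H]12`) gives 0.08 ug/mL and these two values lie within the scatter of each other. Compound 3 (`COC(=O)C1=CO[C@@H](O[C@@H]2O[C@H](COC(=O)c3cccc([N+](=O)[O-])c3)[C@@H](OC(C)=O)[C@H](OC(C)=O)[C@H]2OC(C)=O)[C@@H]2[C@@H](C)[C@@H](OC(C)=O)C[C@H]12`) carries 3-nitrophenyl in place of 2-methylprop-1-en-1-yl on a carbonyl carbon and is still unmeasured. Among the compounds with values here, the only measured step at this place (a 2.0-fold higher number from compound 1 to compound 2 (0.30 log units; within the scatter)) exchanged undecyl for 2-methylprop-1-en-1-yl, and no measured compound carries an aromatic ring there. The expected step in this assay is therefore small (a 1.3-fold higher number from compound 2 to compound 3 (0.10 log units; within the scatter)) and no larger than the scatter. Compound 3 is estimated at 0.1 ug/mL with a range of 0.03 ug/mL to 0.3 ug/mL as expected bounds.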

Compound 3, half-maximal inhibitory concentration: 0.44 ug/mL
The estimate for compound 3 lay 4.4-fold (0.64 log units) below the measured number, and the stated range ends below it.
By their numbers in this assay, from the lowest: compounds 1 and 2 (each within the scatter of the next); then compound 3.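

In this assay the position on this carbonyl carbon proves not to be indifferent to the group it carries: 3-nitrophenyl in place of 2-methylprop-1-en-1-yl gives a 5.5-fold higher number from compound 2 to compound 3 (0.74 log units; beyond the scatter), and 3-nitrophenyl in place of undecyl gives an 11-fold higher number from compound 1 to compound 3 (1.04 log units; beyond the scatter). Among these compounds, only compound 3 has an aromatic ring here, and only its steps lie beyond the scatter. Nothing available accounts for this shift. Going by these compounds, whether the step belongs to the ring or to its nitro group remains open; an unsubstituted phenyl or a 3-aminophenyl at this place would separate the two.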